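Chloro for methoxy on the aromatic ring of compound 2

The source may hold more compounds than are shown below. What is called first, only, known or untested is meant among the compounds shown, and "the series" means these compounds.

The measured compounds are compound 1, `CNC(=S)NCCC(O)c1ccccc1N`, with 20.7%; compound 2, `CNC(=S)NCCC(O)c1cc(OC)ccc1N`, with 76.6%; and compound 3, `CCNC(=O)NCCC(O)c1cc(OC)ccc1N`, with 26.6%.

In an assay for inhibition of Nitric oxide synthase, inducible (Homo sapiens), read by scintillation counting, with a stated time of 30 min, tested at 1 mM (on this read-out higher numbers stand for more inhibition at the one concentration tested (going by the name of the read-out) and lower numbers for less inhibition), compound 2 stands highest of the three numbers: compound 3 sits a number 50 percentage points lower from compound 2 to compound 3 (beyond the scatter) and compound 1 sits a number 55.9 percentage points higher from compound 1 to compound 2 (beyond the scatter) in the other direction, both beyond the scatter. The unmeasured compound 4, `CNC(=S)NCCC(O)c1cc(Cl)ccc1N`, differs from compound 2 by chloro in place of methoxy on an aromatic carbon. The step that bears on this change is a number 55.9 percentage points higher from compound 1 to compound 2 (beyond the scatter), which shows that the aromatic carbon on which the substituent sits is a place where a substituent moved this assay by a large amount. Chloro is a different group from methoxy, and no measured pair shows that exchange, so the direction is uncertain; a step downward from compound 2 beyond the scatter is expected, since the methoxy that gave the gain leaves, but with the thiourea kept the number is expected to stay in the middle of the measured range. The estimate for compound 4 is 50%, between 22% and 78%, a step of a number 26.6 percentage points lower from compound 2 to compound 4 (beyond the scatter).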

Compound 4, a percentage reported as inhibition, at one concentration (the size of the read-out at that concentration, not a potency): 22.1%
Beside the measured number, compound 4's estimate is 27.9 percentage points above it, within the range that was stated.
By their numbers in this assay, from the lowest: compounds 1, 4 and 3 (each within the scatter of the next); then compound 2.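

In this assay the exchange at this aromatic carbon, para to an amino group, gives a number 54.5 percentage points lower from compound 2 to compound 4 (beyond the scatter) and so removes nearly all of the gain that methoxy had brought. Chloro in place of hydrogen gives a number 1.4 percentage points higher from compound 1 to compound 4 (within the scatter) and thus leaves the number where the unsubstituted compound stood. With the methylthiourea chain kept, the high number therefore belongs to methoxy among the three groups compared here, and a substituent on this carbon does not raise the number merely by being there.

The compounds shown offer no explanation for the gap between methoxy and chloro. From the compounds shown here alone, whether other groups on this carbon, such as ethoxy, hydroxy or an amine, would give a number like that of methoxy or like that of chloro remains open.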